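The source may report more compounds than this note shows. Statements on the series, on what has been measured and on what is new or still open speak of the compounds shown alone.

Among the measured compounds shown here, compound 1 `CC/C(=C\[C@@]1(CC)C[C@H](CC)[C@H](CC(=O)OC)OO1)[C@H]1O[C@H]1CC` is the only compound in this set with a numbered result in a functional assay on P388 cells (Mus musculus) for cytotoxicity; on this read-out lower numbers stand for an effect already at smaller amounts and higher numbers for an effect only at larger amounts of compound: compound 1 gives 1.1 ug/mL. Compound 2 `CCCCCCCCCCCCCCCC[C@@]1(OC)C=C[C@@H](CC(=O)OC)OO1` in this assay reaches only a limit, > 10 ug/mL, and no number; this is the limit of > 10 ug/mL in this assay, at which 1 of the 2 values shown sits. Compound 3 `CC/C(=C\[C@@]1(CC)C[C@H](CC)[C@H](CC(=O)OC)OO1)[C@@H]1O[C@@H]1CC` is the counterpart of compound 1 in which (the two compounds have the same atoms and bonds and differ only in configuration as drawn: 2 of 6 stereo elements differ; a stereocentre at a saturated ring carbon is drawn R in compound 1 and S in compound 3; a stereocentre at a saturated ring carbon is drawn S in compound 1 and R in compound 3). For the measured compounds named here, no measured step of this kind exists in the set, so the change is expected to shift the this assay value by no more than a modest amount, if at all, and most likely toward larger amounts. For compound 3 a value of 2 ug/mL is estimated, in the range 0.5 ug/mL to 8 ug/mL, which means an expected step of a 1.8-fold higher number from compound 1 to compound 3 (0.26 log units; within the scatter).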

Compound 3, concentration for half-maximal effect: 0.91 ug/mL
Estimate against measurement, compound 3: 2.2-fold (0.34 log units) above, and the stated range covers the measured number.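

Among the compounds shown here, the swap at the two stereocentres on saturated ring carbons gives the first measured step, and in this assay it reads a 1.2-fold lower number from compound 1 to compound 3 (0.08 log units; within the scatter). At these two carbons, the configuration as drawn therefore leaves the read-out indistinguishable between the pair. Any comparison of this pair rests on a single structural difference: the fact that compounds 1 and 3 differ only in the configuration as drawn.

The compounds shown leave open whether the other four stereo elements tolerate the same swap. Also open, going by these compounds, is what a carboxylic acid in place of the methyl ester would give in this assay.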